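The source may report more compounds than this note shows. Statements on the series, on what has been measured and on what is new or still open speak of the compounds shown alone.

Values in a functional assay on WM 266-4 cells (Homo sapiens) for inhibition, with a stated time of 72 h; a lower number here means a stronger inhibitor, a higher number a weaker inhibitor:
- compound 1 `CNC(=O)C1=C[C@@H]2[C@@H](C(C)C)CC[C@@](O)(CO)[C@H]2C(=O)OC1`: > 32000 nM
- compound 2 `COC(=O)C1=C[C@@H]2[C@@H](C(C)C)CC[C@@]3(CO3)[C@H]2C(=O)OC1`: 4100 nM
- compound 3 `CC(C)[C@H]1CC[C@@](O)(CCl)[C@H]2C(=O)OCC(C(=O)OCc3ccc(-c4ccccc4)o3)=C[C@H]12`: 2910 nM

Compound 1 stands at > 32000 nM, which is a limit of the assay and not a number. Compound 2 at 4100 nM and compound 3 at 2910 nM both return numbers in this assay. Among the measured compounds shown here, each differs from compound 1 in more than one place, so neither gives a clean single-change step, and no such step exists anywhere so far.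

Next in line is compound 4 `CC(C)[C@H]1CC[C@@](O)(CO)[C@H]2C(=O)OCC(C(=O)O)=C[C@H]12`, still to be measured in this assay. Relative to compound 1, the change is hydroxy in place of methylamino on a carbonyl carbon, or methylcarbamoyl to carboxy when cut one bond further out. The rest of the structure is unchanged.

For the measured compounds named here, with no measured step to guide it, the expectation rests on compound 1 and its reading of > 32000 nM. No step beyond the scatter is expected, and a further limit reading is the likelier outcome. The estimated step is an at least 1.0-fold lower number from compound 1 to compound 4 (0.02 log units; that floor lies within the scatter). For compound 4 the expected value is 30000 nM, with an estimated range of 10000 nM to 60000 nM.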

Compound 4, half-maximal inhibitory concentration: > 32000 nM
Compound 4: no number, only a limit; the forecaster's own chance of this, stated with the estimate: 70%; middle value at least 1.0-fold (0.02 log units) away from the limit.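

In this assay compound 4 gives > 32000 nM, a limit and not a number. Compound 1 also sits at a limit, and no step can be read between compound 1 and compound 4. The compounds shown leave open whether hydroxy in place of methylamino on a carbonyl carbon shifts the read-out in this assay at all.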